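A few compounds are considered here, and "the series" means these few. Any claim that something is new, unique, unknown or untested is made for them only; others in the source may bear on it.

Measured compounds:
compound 1 `CC(=O)N1N=C(c2ccc3ccccc3c2)OC1c1ccc(Br)cc1` — 2.08 ug/mL
compound 2 `CC(=O)N1N=C(c2ccc3ccccc3c2)OC1c1ccccc1Cl` — 4.32 ug/mL
compound 3 `CC(=O)N1N=C(c2ccc3ccccc3c2)OC1c1ccccn1` — 5.26 ug/mL

All three share one core and differ only in the group on a saturated ring carbon; the read-out is a functional assay on HepG2 cells (Homo sapiens) for antiproliferative activity, read by MTT assay, with a stated time of 48 h; on this read-out higher numbers stand for weaker inhibition and lower numbers for stronger inhibition. On the three numbers compound 2 gives the second highest; compound 3 is nearest, higher by an amount within the scatter, and compound 1 is furthest, the gap being a 2.1-fold higher number from compound 1 to compound 2 (0.32 log units; beyond the scatter).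

Compound 4 `CC(=O)N1N=C(c2ccc3ccccc3c2)OC1c1ccncc1` is not yet measured. It differs from compound 2 thus: pyridin-4-yl in place of 2-chlorophenyl on a saturated ring carbon.

Among the compounds with values here, two measured steps bear on this change. The step of a 1.2-fold higher number from compound 2 to compound 3 (0.09 log units; within the scatter) starts from the same 2-chlorophenyl and puts a pyridin-2-yl in its place, and lies within the scatter. The step of a 2.5-fold higher number from compound 1 to compound 3 (0.40 log units; beyond the scatter) also ends at a pyridin-2-yl, from 4-bromophenyl, and is modest. Within the data shown here, no measured step places a pyridin-4-yl, so the pyridin-2-yl steps are the closest guide, and they suggest the 2-chlorophenyl and a pyridine give similar numbers.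

In this assay the expected step is therefore a 1.3-fold higher number from compound 2 to compound 4 (0.10 log units; within the scatter), none beyond the scatter. Compound 4 is estimated at 5.5 ug/mL, with a range from 2.7 ug/mL to 11 ug/mL.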

Compound 4, half-maximal inhibitory concentration: 2.17 ug/mL
The estimate for compound 4 lay 2.5-fold (0.40 log units) above the measured number; measured number below the stated range.
By their numbers in this assay, from the lowest: compounds 1, 4, 2 and 3 (each within the scatter of the next, the first and the last beyond it).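

In this assay, within the data shown here, the pyridine group on this saturated ring carbon can no longer be treated as a single case: pyridin-4-yl in place of pyridin-2-yl gives a 2.4-fold lower number from compound 3 to compound 4 (0.38 log units; beyond the scatter), the only new step beyond the scatter. Pyridin-4-yl cannot be separated from the 2-chlorophenyl group, with a 2.0-fold lower number from compound 2 to compound 4 (0.30 log units; within the scatter), or from the 4-bromophenyl group, with a 1.0-fold higher number from compound 1 to compound 4 (0.02 log units; within the scatter), so a ring with a hetero atom at this carbon can match both halogen-bearing phenyl groups in this series, while the pyridin-2-yl of compound 3 remains beyond the scatter of compound 1. Nothing available explains the gap between the two pyridines.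

From the compounds shown here alone, it remains open whether pyridin-3-yl would fall with pyridin-4-yl, with pyridin-2-yl or elsewhere, and where an unsubstituted phenyl would stand as a common reference for all four groups. Also open, going by these compounds, is how an amine or a carboxylic acid on the phenyl ring at this carbon would read in this assay, and whether the gap between the two pyridines would persist with a longer acyl chain in place of the acetyl group.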